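The compounds below may be only part of what the source reports. "The series", "measured", "known", "first", "only" and "open" are said of these compounds alone.

Measured compounds in an assay on isolated protein for inhibition of serine/threonine-protein kinase TNNI3K (Homo sapiens); on this read-out lower numbers stand for stronger inhibition and higher numbers for weaker inhibition:
compound 1 `CNc1cc(Oc2ccc(NC(=O)Nc3cccc(C(F)F)c3)cc2)ncn1` gives 100 nM
compound 2 `O=C(Nc1ccc(Oc2cc(O)ncn2)cc1)Nc1cccc(C(F)(F)F)c1` gives 3200 nM
compound 3 `CNc1cc(Oc2ccc(NC(=O)Nc3cccc(C(F)(F)F)c3)c(F)c2F)ncn1` gives 20 nM

Compound 2 stands at the highest number of the three. Compound 1 lies a long way below it, and compound 3 further still; both gaps are well beyond the scatter of repeated measurements. Compound 1 and compound 3 carry other substituents at the place where compound 2 bears its hydroxy group, and they differ from compound 2 elsewhere as well, so no single change accounts for the gap.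

Compound 4 `Cc1cc(Oc2ccc(NC(=O)Nc3cccc(C(F)(F)F)c3)cc2)ncn1` has not yet been measured in this assay. It differs from compound 2 in one place: methyl in place of hydroxy on an aromatic carbon. Among the compounds with values here, no step between measured compounds isolates this change. Since compound 2 gives 3200 nM while compounds with other groups at that place give far lower numbers, the expectation is a step downward, beyond the scatter, an 8.0-fold lower number from compound 2 to compound 4 (0.90 log units; beyond the scatter). Compound 4 is estimated at 400 nM, within the range 100 nM to 1600 nM.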

Compound 4, half-maximal inhibitory concentration: 160 nM
Estimate against measurement, compound 4: 2.5-fold (0.40 log units) above; low and high end bracket the measured number.
By their numbers in this assay, from the lowest: compound 3; then compounds 1 and 4 (each within the scatter of the next); then compound 2.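

In this assay, a step of a 20-fold lower number from compound 2 to compound 4 (1.30 log units; beyond the scatter) comes from exchanging hydroxy for methyl alone, turning the 6-hydroxypyrimidin-4-yl group into 6-methylpyrimidin-4-yl while the rest of the structure stays the same. Within the data shown here, the earlier compounds differed from compound 2 in more than one place, so this is the first large change that can be tied to this position and nothing else: the group that leaves has one hydrogen-bond donor and one acceptor, and the group that enters has neither. Nothing shown explains why the number falls.

As far as these compounds go, it remains open whether methoxy, chlorine or a longer chain such as ethyl at this place would give a number like that of compound 4 or a different one. From the compounds shown here alone, whether the same exchange gives a step of similar size on the core of compound 3 also remains open.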